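The compounds below may be only part of what the source reports. "The series", "measured", "known", "first", "only" and "open" are said of these compounds alone.

Notes on the series in a physicochemical assay for solubility, in phosphate buffer, measured as kinetic solubility, at pH 7.4; on this read-out higher numbers stand for higher solubility and lower numbers for lower solubility. Compound 1 (`Cc1oc(-c2c(Cl)cccc2Br)nc1CN1CCC(C(=O)NCCCN2C[C@H](C)C[C@H](C)C2)CC1`) gives > 83 ug/mL, a limit. Compound 2 (`Cc1cccc(F)c1-c1nc(CN2CCC(C(=O)NCCCN3C[C@H](C)C[C@H](C)C3)CC2)c(C)o1`) gives > 72 ug/mL, also a limit. Compound 3 (`Cc1cccc(-c2nc(CN3CCC(C(=O)NCCCN4C[C@H](C)C[C@H](C)C4)CC3)c(C)o2)c1`) gives > 69 ug/mL, likewise a limit and not a number. Compound 4 (`CCc1ccccc1-c1nc(CN2CCC(C(=O)NCCCN3C[C@H](C)C[C@H](C)C3)CC2)c(C)o1`) carries 2-ethylphenyl in place of the 3-methylphenyl of compound 3: 2-ethylphenyl in place of 3-methylphenyl on an aromatic carbon. Three measured changes of this same group bear on it: a step that the two limits leave unreadable from compound 1 to compound 2, a step that the two limits leave unreadable from compound 1 to compound 3 and a step that the two limits leave unreadable from compound 2 to compound 3. None of them gives a size, so no step beyond the scatter is expected in this assay, in either direction. The expected step is a step that the limit leaves unreadable from compound 3 to compound 4. Compound 4 is estimated at 75 ug/mL, with an expected range of 45 ug/mL to 100 ug/mL.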

Compound 4, solubility: 55.9 ug/mL
For compound 4 the middle estimate is 1.3-fold (0.13 log units) above the measured one, and the stated range covers the measured number.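

Going by these compounds alone, at this position on the shared core, 2-ethylphenyl gives the first real number in this assay, whereas the earlier groups gave only limits, and the steps among them cannot be read. Against those compounds the result is an at least 1.2-fold lower number from compound 3 to compound 4 (0.09 log units; that floor lies within the scatter), an at least 1.2-fold lower number from compound 2 to compound 4 (0.10 log units; that floor lies within the scatter) and an at least 1.4-fold lower number from compound 1 to compound 4 (0.17 log units; that floor lies within the scatter). As far as these compounds go, each of these is only a floor, so the true size of each step stays unknown.

Also open, from the compounds shown here alone, is whether a phenyl group carrying an amine or a carboxylic acid at this position would give a number or a limit.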